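Branched alkyl variation at the ring position next to nitrogen

The source may hold more compounds than are shown below. What is called first, only, known or untested is meant among the compounds shown, and "the series" means these compounds.

For the measured compounds named here, compound 1 `CC(C)(C)c1cc(N)c2cc(NC(=O)/C=C/c3ccc(C(F)(F)F)cc3)ccc2n1` gives 0.3 nM in an assay on isolated protein for displacement of a labelled ligand from melanin-concentrating hormone receptor 1 (Homo sapiens) (a higher number here means a weaker inhibitor, a lower number a stronger inhibitor), and stands lowest of the three numbers so far; compound 3 `CCCc1cc(N)c2cc(NC(=O)/C=C/c3ccc(SC)cc3)ccc2n1` gives 9 nM, and compound 2 `CCCc1cc(N)c2cc(NC(=O)/C=C/c3ccc(F)cc3)ccc2n1` gives 130 nM. Going by the values given here, the one single-point step among the measured compounds is a 14-fold lower number from compound 2 to compound 3 (1.16 log units; beyond the scatter), a change on the aryl ring at the far end of the amide, not at the site now in question.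

Compound 4 `CCC(C)c1cc(N)c2cc(NC(=O)/C=C/c3ccc(C(F)(F)F)cc3)ccc2n1` differs from compound 1 by sec-butyl in place of tert-butyl on an aromatic carbon. Among the compounds with values here, no measured pair in this set changes the alkyl group at that position while holding the rest constant; compounds 2 and 3 carry propyl there but also differ from compound 1 on the aryl ring, so their numbers cannot be attributed to the alkyl group alone. The change keeps atom count and ring pattern, so a step within the scatter or a small loss is the working assumption. Compound 4 is therefore expected to show a 2.0-fold higher number from compound 1 to compound 4 (0.30 log units; within the scatter) in this assay, with an estimate of 0.6 nM and a range of 0.15 nM to 3 nM.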

Compound 4, half-maximal inhibitory concentration: 0.3 nM
Estimate against measurement, compound 4: 2.0-fold (0.30 log units) above, and the stated range covers the measured number.
By their numbers in this assay, from the lowest: compounds 1 and 4 (each within the scatter of the next); then compound 3; then compound 2.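

For the compounds shown here, at the alkyl position, the first pair that changes only this group gives no change at the digits printed from compound 1 to compound 4 (within the scatter) in this assay, so tert-butyl and sec-butyl cannot be told apart here with the trifluoromethyl aryl end held constant. A third methyl group on the carbon attached to the aromatic ring is therefore not needed to keep the value of compound 1, which compounds 2 and 3 could not show, as they also differ from compound 1 on the aryl ring. Nothing available explains why the two isomers read alike.

Still open, as far as these compounds go, is whether isopropyl, cyclopropyl, or a chain carrying an amine would hold this value at the same position. Also open, from the compounds shown here alone, is how propyl compares with either butyl group when the aryl ring carries trifluoromethyl, and whether the match between the two butyl groups persists with methylsulfanyl or fluoro on that ring.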